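High-solubility series: dipropylamino replacing dimethylamino on the side chain

The source may report more compounds than this note shows. Statements on the series, on what has been measured and on what is new or still open speak of the compounds shown alone.

Compound 1 `CCCN(CCC)CCNc1n[n+]([O-])c2ccccc2[n+]1[O-]` reaches only a limit of the assay in a physicochemical assay for solubility, in the presence of a further agent that is not named here (a higher number here means a more soluble compound, a lower number a less soluble compound), reported as > 25000000 nM. That reading is a limit and not a number, a point recorded as the limit of > 25000000 nM in this assay, at which 1 of the 2 values shown sits. Among the compounds with values here, compound 2 `CN(C)CCNc1n[n+]([O-])c2ccc(C(C)(C)C)cc2[n+]1[O-]` is the one compound of the two with a measured number, giving 38000000 nM in this assay; among the values shown it is the only figure that is not a limit, so no ranking of compound 2 against compound 1 can be drawn from these two readings.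

Compound 3 `CCCN(CCC)CCNc1n[n+]([O-])c2ccc(C(C)(C)C)cc2[n+]1[O-]` has not been measured. It differs from compound 2 by one change: dipropylamino in place of dimethylamino on a saturated chain carbon, two bonds along the chain from a nitrogen on an aromatic ring. Within the data shown here, no step between measured compounds covers this change. The expected step in this assay from compound 2 to compound 3 is small and is not expected to go beyond the scatter, estimated as a 1.3-fold lower number from compound 2 to compound 3 (0.10 log units; within the scatter). Compound 3 is therefore expected to give about 30000000 nM, within a range from 10000000 nM to 60000000 nM.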

Compound 3, solubility: 32000000 nM
Estimate against measurement, compound 3: 1.1-fold (0.03 log units) below; the range from low to high includes it.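

In this assay, within the data shown here, the first readable step at this position, dipropylamino in place of dimethylamino on a saturated chain carbon, two bonds along the chain from a nitrogen on an aromatic ring, gives a 1.2-fold lower number from compound 2 to compound 3 (0.07 log units; within the scatter). On the tert-butyl core, this pair therefore shows no separation between the two side-chain amines in this assay, even though the entering group has more heavy atoms than the one it replaces; this holds for this single pair only. The other new step, tert-butyl in place of hydrogen on an aromatic carbon, cannot be read because compound 1 gives a limit and not a number: the limit of > 25000000 nM in this assay, at which 1 of the 3 values shown sits.

Still open, from the compounds shown here alone, is whether a longer chain such as dibutylamino, or a cyclic amine such as morpholine, in the same place would also stay within the scatter of compound 2. Also open, going by these compounds, is whether the swap between dimethylamino and dipropylamino reads the same way with hydrogen in place of tert-butyl, and what tert-butyl itself contributes to the read-out.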